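This account rests on a few compounds, and the source may have more. Where it says the series, first, only, none or still open, it means among the compounds named here.

Compound 1 `COC(=O)C1=C(CN2CCOCC2=O)NC(c2nccs2)=NC1(C)c1ccc(F)cc1` is the reference point. In an ADME assay on microsomes from liver (Mus musculus) for metabolic stability, read by LC-MS, using NADPH, with stated times of 10 min and 30 min, tested at 1 uM (a lower number here means slower removal, a higher number faster removal of the compound), compound 1 gives 80 mL/min/kg, the low end of the three numbers in hand, though every step to the others lies within the scatter. Compound 2 `COC(=O)C1=C(CN2CCC(O)CC2)NC(c2nccs2)=NC1(C)c1ccc(F)cc1` gives 81 mL/min/kg and compound 3 `COC(=O)C1=C(CN2CCC(F)(F)CC2)NC(c2nccs2)=NC1(C)c1ccc(F)cc1` gives 88 mL/min/kg; the steps are a 1.0-fold higher number from compound 1 to compound 2 (0.01 log units; within the scatter), a 1.1-fold higher number from compound 1 to compound 3 (0.04 log units; within the scatter) and a 1.1-fold higher number from compound 2 to compound 3 (0.04 log units; within the scatter). Compound 4 `COC(=O)C1=C(COCC(F)(F)F)NC(c2nccs2)=NC1(C)c1ccc(F)cc1` differs from compound 1 by 2,2,2-trifluoroethoxy in place of 3-oxomorpholin-4-yl on a saturated chain carbon bound to a double-bonded ring carbon. The measured steps each replace the same group with another ring; none replaces it with an open chain, so they bear only loosely on this change. They show no movement beyond the scatter, so no step beyond the scatter is expected here either: a 1.1-fold higher number from compound 1 to compound 4 (0.03 log units; within the scatter). Compound 4 is therefore estimated at 85 mL/min/kg, with a range from 55 mL/min/kg to 130 mL/min/kg.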

Compound 4, clearance: 81 mL/min/kg
For compound 4 the middle estimate is 1.0-fold (0.02 log units) above the measured one; low and high end bracket the measured number.
By their numbers in this assay, from the lowest: compounds 1, 2, 4 and 3 (each within the scatter of the next).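

Replacing the ring with the open 2,2,2-trifluoroethoxy chain on a saturated chain carbon bound to a double-bonded ring carbon still moves no number beyond the scatter in this assay (a 1.0-fold higher number from compound 1 to compound 4 (0.01 log units; within the scatter); no change at the digits printed from compound 2 to compound 4 (within the scatter); a 1.1-fold lower number from compound 3 to compound 4 (0.04 log units; within the scatter)). At this position, the four compounds therefore show no separation between ring and open-chain groups. No measurement at hand explains why the numbers stay together.

Still open, going by these compounds, is whether a carboxylic acid or an open-chain amine here would give a step beyond the scatter.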